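From naphthalen-1-yl to naphthalen-2-yl in compound 2

The compounds below may be only part of what the source reports. "The series", "measured", "known", "first", "only" and "open" are said of these compounds alone.

Compound 1 `C=C(c1cccc2ccccc12)C1CCC2(CC1)COC(Nc1ccc(F)cc1)OO2`: 5.75
Compound 2 `C=C(c1cccc2ccccc12)C1CCC2(CC1)COC(Nc1ccc(Cl)cc1)OO2`: 6.15
Compound 3 `C=C(c1cccc2ccccc12)C1CCC2(CC1)COC(Nc1ccc(C(F)(F)F)cc1)OO2`: 6.51

These three compounds were measured in a physicochemical assay for lipophilicity (on this read-out higher numbers stand for higher lipophilicity and lower numbers for lower lipophilicity), and differ in one group on an aromatic carbon. Compound 2 is second highest of the three, with 6.15 as its value. The step above it is a number 0.36 log units higher from compound 2 to compound 3 (beyond the scatter) and the step below it is a number 0.40 log units higher from compound 1 to compound 2 (beyond the scatter), both modest. The widest gap, also modest, is a number 0.76 log units higher from compound 1 to compound 3 (beyond the scatter).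

The next step leads to compound 4 `C=C(c1ccc2ccccc2c1)C1CCC2(CC1)COC(Nc1ccc(Cl)cc1)OO2`, and the change is naphthalen-2-yl in place of naphthalen-1-yl on a double-bonded chain carbon bound to a saturated ring carbon. It puts naphthalen-2-yl in place of naphthalen-1-yl on a double-bonded chain carbon bound to a saturated ring carbon. Among the measured compounds shown here, none of the measured steps touches this place. All three exchange fluoro, chloro or trifluoromethyl on an aromatic carbon, and they give only a rough sense of how large a single exchange has been in this small set. For the measured compounds named here, with no measured pair to go on, no step beyond the scatter is expected in this assay and no direction is firmly favoured, so the expectation starts from compound 2 at 6.15 as its anchor. The estimate amounts to a number 0.05 log units higher from compound 2 to compound 4 (within the scatter) as the expected step. For compound 4 the estimated value is 6.2 with an expected range from 5.8 to 6.6 as its limits.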

Compound 4, partition coefficient: 6.15
Estimate against measurement, compound 4: 0.05 log units above; low and high end bracket the measured number.
By their numbers in this assay, from the lowest: compound 1; then compounds 2 and 4 (each within the scatter of the next); then compound 3.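

In this assay, putting naphthalen-2-yl in place of naphthalen-1-yl on a double-bonded chain carbon bound to a saturated ring carbon gives no change at the digits printed from compound 2 to compound 4 (within the scatter), the only reading at this place among the compounds shown. The earlier steps shown here all exchanged fluoro, chloro or trifluoromethyl on an aromatic carbon and each lay beyond the scatter, whereas this exchange, which keeps the same atoms joined differently, separates compound 2 and compound 4 by nothing that can be told apart on this read-out. Nothing available explains why the two read alike, and no further measurement bears on the result.

The compounds shown leave open whether this exchange would also read alike with fluoro or trifluoromethyl in place of chloro on the aromatic carbon, as naphthalen-2-yl appears here only alongside chloro. They also leave open how this assay would respond to a different kind of group on the same chain carbon, such as a phenyl ring, a carboxylic acid or an amine, in place of either naphthalene group.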